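The compounds below may be only part of what the source reports. "The series", "measured", "known", "first", "only" and "open" are said of these compounds alone.

Measured compounds:
Compound 1 `O=C(/C=C/c1ccc2c(c1)B(O)OC2)c1ccc(I)cc1` gives in an ADME assay on L929 cells (Mus musculus) for cytotoxicity, read by resazurin assay, with a stated time of 72 h (on this read-out higher numbers stand for weaker inhibition and lower numbers for stronger inhibition), a limit of > 10 ug/mL.
Compound 2 `O=C(/C=C/c1ccc2c(c1)B(O)OC2)c1ccc(Br)cc1` gives in this assay a limit of > 10 ug/mL.
Compound 3 `CCOC(=O)c1ccc(C(=O)/C=C/c2ccc3c(c2)B(O)OC3)cc1` gives in this assay a limit of > 10 ug/mL.

Compound 3 thus stands at a limit rather than at a number, and the two other values stand there as well, as the limit of > 10 ug/mL in this assay, at which 3 of the 3 values shown sit, shows. The change to compound 4 `CC(=O)Nc1ccc(C(=O)/C=C/c2ccc3c(c2)B(O)OC3)cc1` is acetamido in place of ethoxycarbonyl on an aromatic carbon. The measured steps a step that the two limits leave unreadable from compound 1 to compound 2, a step that the two limits leave unreadable from compound 1 to compound 3 and a step that the two limits leave unreadable from compound 2 to compound 3 each join two limits, so none has a readable size, and none gives a readable lesson for the move to acetamido. In this assay no step beyond the scatter is therefore expected in either direction. Compound 4 is expected to give about 20 ug/mL, between 6 ug/mL and 60 ug/mL. The expected step that the limit leaves unreadable from compound 3 to compound 4 is estimated to stay within the scatter.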

Compound 4, half-maximal inhibitory concentration: > 10 ug/mL
Compound 4 gave a limit, no number (the forecaster's own chance of this, stated with the estimate: 80%); the middle value lies beyond the limit too.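

The steps from compound 1, compound 2 and compound 3 to compound 4 cannot be read, as all four compounds stand at a limit rather than a number: the limit of > 10 ug/mL in this assay, at which 4 of the 4 values shown sit.

What the compounds shown leave open is whether these four differ at all in this assay, and where any of their actual values lie.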